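A few compounds are considered here, and "the series" means these few. Any claim that something is new, unique, unknown or untested is made for them only; others in the source may bear on it.

Compound 1, `CC(C)C[C@H](N)CN(C(=O)[C@@H]1C[C@H]1c1ccccc1)c1ccc(-c2ccccc2)cc1`: 880 nM
Compound 2, `CCC(C)CNCCN(C(=O)[C@@H]1C[C@H]1c1ccccc1)c1ccc(-c2ccccc2)cc1`: 4.7 nM
Compound 3, `CC(C)C[C@H](N)CN(C(=O)[C@@H]1C[C@H]1c1ccccc1)c1ccc(-c2cccnc2)cc1`: 10000 nM

All three compounds were tested in a functional assay for agonist activity at G protein-coupled receptor 88 (Homo sapiens), read by HTRF and cAMP accumulation; a lower number here means that less compound is needed, a higher number that more compound is needed for the effect. Compound 3 gives the highest number of the three. Among the measured compounds shown here, its nearest neighbour is compound 1, and the step of an 11-fold higher number from compound 1 to compound 3 (1.06 log units; beyond the scatter) separates them; the only change in that step is that a pyridin-3-yl replaces the outer phenyl ring on the shared core. The furthest away is compound 2, which in this assay gives 4.7 nM, while compound 3 gives 10000 nM. The step of a 190-fold lower number from compound 1 to compound 2 (2.27 log units; beyond the scatter) concerns a different part of the molecule, the amine-bearing chain, and so says nothing directly about the outer ring.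

Compound 4, `CC(C)C[C@H](N)CN(C(=O)[C@@H]1C[C@H]1c1ccccc1)c1ccc(-c2ccncc2)cc1`, is compound 3 with the change (pyridin-4-yl in place of pyridin-3-yl on an aromatic carbon). For the measured compounds named here, no measured step compares one pyridine with another, so the only guidance is that the phenyl-to-pyridin-3-yl step was large and unfavourable. Moving the ring nitrogen from one position to another is expected to change little, so the step of no change at the digits printed from compound 3 to compound 4 (within the scatter) is estimated to lie within the scatter. Compound 4 is therefore expected to give about 10000 nM in this assay, with a range from 3000 nM to 30000 nM.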

Compound 4, half-maximal effective concentration: 13000 nM
Compound 4: middle estimate off by 1.3-fold (0.11 log units), on the low side; measured number inside the range.
By their numbers in this assay, from the lowest: compound 2; then compound 1; then compounds 3 and 4 (each within the scatter of the next).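

In this assay the swap of pyridin-3-yl for pyridin-4-yl gives a 1.3-fold higher number from compound 3 to compound 4 (0.11 log units; within the scatter) and so, at this place on the ring, para to a large group, the two pyridines cannot be told apart. The earlier compounds shown here showed the cost of a ring nitrogen for only one pyridine, whereas now the step of a 15-fold higher number from compound 1 to compound 4 (1.17 log units; beyond the scatter) is large just as the step of an 11-fold higher number from compound 1 to compound 3 (1.06 log units; beyond the scatter) is, and both nitrogen positions go with a higher number than the phenyl of compound 1. No measurement at hand offers an explanation for this pattern.

The compounds shown leave open whether a phenyl carrying a fluorine or a methoxy group at this place would stay close to compound 1 or move towards compounds 3 and 4. Going by these compounds, it is also open whether the ((2-methylbutyl)amino)methyl chain of compound 2 would bring down the number of a compound with a pyridine ring as far as it does with the phenyl.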